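The source may hold more compounds than are shown below. What is called first, only, known or untested is meant among the compounds shown, and "the series" means these compounds.

Compound 1 `Nc1c(C(=O)NCc2ccc(F)cc2F)c(=O)n(O)c2ncc(CCCC3CCCCC3)cc12`: 27400 nM
Compound 2 `Nc1c(C(=O)NCc2ccc(F)cc2F)c(=O)n(O)c2ncc(/C=C/C(=O)NCCO)cc12`: > 250000 nM

In an ADME assay on HOS cells (Homo sapiens) for cytotoxicity, read by luminescence and ATP content, with a stated time of 48 h (on this read-out higher numbers stand for lower toxicity in this test and lower numbers for higher toxicity in this test), compound 2 gives > 250000 nM, which is a limit of the assay and not a number. Compound 3 `COC(=O)CCc1cnc2c(c1)c(N)c(C(=O)NCc1ccc(F)cc1F)c(=O)n2O` carries 2-(methoxycarbonyl)ethyl in place of 2-((2-hydroxyethyl)carbamoyl)ethenyl on an aromatic carbon. Among the measured compounds shown here, only one measured step bears on this, an at least 9.1-fold higher number from compound 1 to compound 2 (0.96 log units; beyond the scatter), and it removed 3-cyclohexylpropyl. The chain in compound 3 has no ring, like the group it replaces, so at most a small move toward lower numbers is expected in this assay. The expected step is an at least 1.5-fold lower number from compound 2 to compound 3 (0.19 log units; that floor lies within the scatter). The estimate for compound 3 is 160000 nM, with an expected range of 60000 nM to 300000 nM.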

Compound 3, half-maximal cytotoxic concentration: > 250000 nM
Compound 3 was reported as a limit (the forecaster's own chance of this, stated with the estimate: 40%); middle value at least 1.5-fold (0.19 log units) away from the limit.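

In this assay the move away from the ring-bearing chain gives an at least 9.1-fold higher number from compound 1 to compound 3 (0.96 log units; beyond the scatter) even though the new chain has none of the hydrogen-bond donors and no ethenyl link of the group in compound 2. The higher number at this position therefore does not depend on those features. The result for compound 3 is a limit of the assay, not a number, so the step from compound 2 cannot be read: the limit of > 250000 nM in this assay, at which 2 of the 3 values shown sit.

Whether the cyclohexyl ring or the length of the chain lies behind the lower number of compound 1 stays open. So does how an amine or a longer chain without a ring would read on this aromatic carbon.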